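Stretching the Short Chain of Compound 3

The source may report more compounds than this note shows. Statements on the series, on what has been measured and on what is new or still open speak of the compounds shown alone.

Going by the values given here, in a functional assay on CNE-2 cells (Homo sapiens) for inhibition, read by MTT assay, with a stated time of 72 h (on this read-out higher numbers stand for weaker inhibition and lower numbers for stronger inhibition), compound 3 `Nc1nc2cc(-c3nn(CC(=O)NO)c4ncnc(N)c34)ccc2o1` gives 12200 nM, the lowest of the three numbers measured so far. Compound 1 `Nc1nc2cc(-c3nn(CCCCCCCCCC(=O)NO)c4ncnc(N)c34)ccc2o1` gives 36800 nM. Compound 2 `Nc1nc2cc(-c3nn(CCCCCC(=O)NO)c4ncnc(N)c34)ccc2o1` gives 37600 nM. Compound 4 `Nc1nc2cc(-c3nn(CCCCCCC(=O)NO)c4ncnc(N)c34)ccc2o1` has 5-(hydroxycarbamoyl)pentyl in place of hydroxycarbamoyl on a saturated chain carbon bound to an aromatic nitrogen. Its chain is shorter than that of compound 1 and longer than that of compound 2. Among the compounds with values here, two measured steps bear on this change. Among the longer chains there is a 1.0-fold higher number from compound 1 to compound 2 (0.01 log units; within the scatter), whereas the shortest chain brings a 3.1-fold lower number from compound 2 to compound 3 (0.49 log units; beyond the scatter). Lengthening should therefore roughly reverse that second step in this assay, and the expected result is a 2.6-fold higher number from compound 3 to compound 4 (0.42 log units; beyond the scatter). Compound 4 is estimated at 32000 nM, with an expected range of 15000 nM to 65000 nM.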

Compound 4, half-maximal inhibitory concentration: 4360 nM
For compound 4 the middle estimate is 7.3-fold (0.87 log units) above the measured one, and the stated range ends above it.
By their numbers in this assay, from the lowest: compound 4; then compound 3; then compounds 1 and 2 (each within the scatter of the next).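

In this assay compound 4, with its 6-(hydroxycarbamoyl)hexyl chain, stands apart from all three earlier compounds: there is a 2.8-fold lower number from compound 3 to compound 4 (0.45 log units; beyond the scatter) and an 8.6-fold lower number from compound 2 to compound 4 (0.94 log units; beyond the scatter) and also an 8.4-fold lower number from compound 1 to compound 4 (0.93 log units; beyond the scatter). Compound 2 has a shorter chain and compound 1 a longer one, so among these four compounds the number does not follow chain length steadily, and one intermediate length gives the lowest value. No measured evidence here explains this result. As far as these compounds go, whether a carboxylic acid in place of the hydroxycarbamoyl end would keep this low number remains open.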